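Chloro in place of phenyl: notes on compound 4

A few compounds are considered here, and "the series" means these few. Any claim that something is new, unique, unknown or untested is made for them only; others in the source may bear on it.

Compound 1 `O=C1COCC(=O)N1CCCCN1CCN(c2ncccc2-c2ccccc2)CC1` is the reference for the step considered here. In an assay on isolated protein for binding affinity to Adrenergic receptor alpha-1 (Rattus norvegicus) (a higher number here means a weaker inhibitor, a lower number a stronger inhibitor), compound 1 gives 16 nM, the second highest of the three numbers recorded so far. The nearest measured neighbour is compound 3 `COC(=O)c1cccnc1N1CCN(CCCCN2C(=O)SC3(CCCC3)C2=O)CC1`, which in this assay gives 7.8 nM, a gap that lies beyond the usual scatter; the furthest is compound 2 `N#Cc1cccnc1N1CCN(CCCCN2C(=O)CSC2=O)CC1`, which in this assay gives 39 nM, also beyond the scatter. Going by the values given here, neither of these two differs from compound 1 in a single place, so no step between measured compounds is available to anchor the change under review.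

Compound 4 `O=C1COCC(=O)N1CCCCN1CCN(c2ncccc2Cl)CC1` differs from compound 1 by chloro in place of phenyl on an aromatic carbon. Among the compounds with values here, no measured pair shows this change, so the expectation rests on the whole series: the three compounds span a narrow band in this assay, and the change takes away a six-membered aromatic ring and brings in a single chlorine on the same ring. A step of modest size toward a higher number is expected, though one within the scatter cannot be excluded. Compound 4 is therefore expected to give 30 nM in this assay, within a range from 10 nM to 90 nM. The expected step is a 1.9-fold higher number from compound 1 to compound 4 (0.27 log units; within the scatter).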

Compound 4, half-maximal inhibitory concentration: 16 nM
Compound 4: the middle estimate sits 1.9-fold (0.27 log units) above what was measured; low and high end bracket the measured number.
By their numbers in this assay, from the lowest: compound 3; then compounds 1 and 4 (each within the scatter of the next); then compound 2.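

In this assay, going by these compounds alone, this is the first step that changes one place only, and it reads no change at the digits printed from compound 1 to compound 4 (within the scatter). At this position, on an aromatic carbon of a six-membered aromatic ring with 1 nitrogen and two atoms from the ring nitrogen, the whole phenyl ring can therefore give way to a lone chloro with no shift in the number, so in this pair the extra aromatic ring is not needed to hold the value. Nothing at hand offers a measured reason why the two groups read alike.

The compounds shown leave open whether this tolerance extends to other groups at the same position, such as a bare hydrogen, a methoxy group, an amine or a carboxylic acid, or whether phenyl and chloro merely happen to coincide. Also open, as far as these compounds go, is whether the same exchange would read alike on a different core, such as that of compound 2 or compound 3, since each of these differs from compound 1 in more than one place.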